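Fluoro for benzyl on the saturated ring carbon

A few compounds are considered here, and "the series" means these few. Any claim that something is new, unique, unknown or untested is made for them only; others in the source may bear on it.

The account concerns compound 1, `CC1(Cc2ccccc2)C(=O)N(c2ccccc2)c2ncccc21`, and an unmeasured relative. In a functional assay on the whole organism (Pleural cavity) for inhibition, with Rattus norvegicus as the target, at a dose of 25 mg/kg (a lower number here means less inhibition, a higher number more inhibition at the dose given (going by the name of the read-out)), compound 1 gives 9%, the lowest of the three numbers shown. Compound 2, `CC1(C)C(=O)N(Cc2ccccc2)c2ncccc21`, gives 12% in this assay, which sits within the scatter of compound 1. Compound 3, `CC1(C)C(=O)N(c2ccc(Br)cc2)c2ncccc21`, gives 46% in this assay, a gap from compound 1 that lies beyond the scatter. No two of the measured compounds differ in a single place, so no single step can be read from them.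

Compound 4, `CC1(F)C(=O)N(c2ccccc2)c2ncccc21`, differs from compound 1 in one place: fluoro in place of benzyl on a saturated ring carbon. Within the data shown here, the measured compounds give no step that isolates a change at this saturated ring carbon; what they show is only that two of the three numbers are low and one is higher.

Compound 4 is expected to stay near the low end, with a step from compound 1 of a number 6 percentage points higher from compound 1 to compound 4 (within the scatter), probably not beyond the scatter. The estimate for compound 4 in this assay is 15%, in a range from 2% to 35%.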

Compound 4, a percentage reported as inhibition, in the whole organism at one dose (the size of the read-out at that dose, not a potency): 50%
Beside the measured number, compound 4's estimate is 35 percentage points below it; measured number outside the range, above it.
By their numbers in this assay, from the lowest: compounds 1 and 2 (each within the scatter of the next); then compounds 3 and 4 (each within the scatter of the next).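

Among these compounds, the step of a number 41 percentage points higher from compound 1 to compound 4 (beyond the scatter) in this assay is the first change confined to this saturated ring carbon, and it shows that the number here is sensitive to what this carbon carries. Benzyl, with 7 heavy atoms and a six-membered aromatic ring, leaves, and fluoro, a single heavy atom, enters; neither group counts any hydrogen-bond donors or acceptors or bears a net charge. Nothing at hand gives a cause for this step.

This one step does not separate the loss of benzyl from the arrival of fluoro, and an amine, a hydroxyl or a chloro on the same carbon would be needed to tell the two apart. On these data alone, whether the step holds on a core with a different group on the ring nitrogen also stays open.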